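Swapping One Halogenated Phenyl for Another

This account rests on a few compounds, and the source may have more. Where it says the series, first, only, none or still open, it means among the compounds named here.

Compound 3 `Nc1scc(CN2CCN(c3cccc(F)c3F)CC2)c1C(=O)c1ccc(Cl)cc1` stands second highest of three numbers in a functional assay on CHO cells with adenosine receptor A1 (Homo sapiens) as the target, read by cAMP accumulation and immunoassay, with a stated time of 6 min, tested at 0.1 uM; a higher number here means a weaker effect of the compound at the concentration tested, a lower number a stronger effect: compound 3 gives -5.2%, close to compound 1 `CC(C)N1CCN(Cc2csc(N)c2C(=O)c2ccc(Cl)cc2)CC1`, which gives 3.6%, and farther from compound 2 `Nc1scc(CN2CCN(c3cccc(C(F)(F)F)c3)CC2)c1C(=O)c1ccc(Cl)cc1`, which gives -30%. Compound 4 `Nc1scc(CN2CCN(c3ccccc3Cl)CC2)c1C(=O)c1ccc(Cl)cc1` differs from compound 3 by 2-chlorophenyl in place of 2,3-difluorophenyl on an amine nitrogen in a ring. Because a number 24.8 percentage points higher from compound 2 to compound 3 (beyond the scatter) also exchanges one phenyl group for another on the same ring nitrogen, it bears most on this change. The other steps, a number 33.6 percentage points lower from compound 1 to compound 2 (beyond the scatter) and a number 8.8 percentage points lower from compound 1 to compound 3 (within the scatter), replace isopropyl with a phenyl group and say less about this swap. A modest step in either direction is possible, but none beyond the scatter is firmly expected. Compound 4 is expected to give -10%, with a range from -35% to 10%. That would be an estimated step of a number 4.8 percentage points lower from compound 3 to compound 4 (within the scatter).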

Compound 4, a percentage reported as activity, at one concentration (the size of the read-out at that concentration, not a potency): 2%
Estimate against measurement, compound 4: 12 percentage points below; low and high end bracket the measured number.
By their numbers in this assay, from the lowest: compound 2; then compounds 3, 4 and 1 (each within the scatter of the next).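

In this assay, 2-chlorophenyl on the ring nitrogen gives a result close to that of 2,3-difluorophenyl, with a number 7.2 percentage points higher from compound 3 to compound 4 (within the scatter), and close to that of isopropyl, with a number 1.6 percentage points lower from compound 1 to compound 4 (within the scatter). Only the 3-(trifluoromethyl)phenyl group stands apart, with a number 32 percentage points higher from compound 2 to compound 4 (beyond the scatter), so this change shows a second halogenated phenyl group staying with isopropyl rather than with that group. Nothing available explains this result.

As far as these compounds go, it remains open whether a 3-chlorophenyl or a 2-(trifluoromethyl)phenyl group would group with compound 2 or with the other three. That comparison would help separate the role of the trifluoromethyl group from the role of its place on the phenyl ring.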